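Ring methyl on a stomach-active thioamide pair

A few compounds are considered here, and "the series" means these few. Any claim that something is new, unique, unknown or untested is made for them only; others in the source may bear on it.

Compound 1, `N=C(S)CCn1ncccc1=O`: in a functional assay on the whole organism (stomach) with Rattus norvegicus as the target (a higher number here means that more compound is needed for the effect, a lower number that less compound is needed), compound 1 gives > 100 mg/kg, which is a limit of the assay and not a number.
Compound 2, `CC(CC(=N)S)n1ncccc1=O`: in this assay compound 2 gives > 100 mg/kg, likewise a limit of the assay.

Compound 2 thus stands only at a limit, and the same holds for the whole set so far: the limit of > 100 mg/kg in this assay, at which 2 of the 2 values shown sit. Among the measured compounds shown here, the one measured step, a step that the two limits leave unreadable from compound 1 to compound 2, joins two limits and its size cannot be read, so it gives no usable measure of how much a single added methyl on the chain shifts the dose.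

Compound 3, `Cc1ccc(=O)n(C(C)CC(=N)S)n1`, differs from compound 2 by methyl in place of hydrogen on an aromatic carbon. For the measured compounds named here, no measured step bears directly on this change; the only measured step concerns the saturated chain, not the ring, and is itself unreadable. With compound 2 sitting at the limit, compound 3 is expected most likely to remain there too, and the step that the limit leaves unreadable from compound 2 to compound 3 is estimated as none beyond the scatter. Compound 3 is therefore estimated at 150 mg/kg in this assay, with a range from 50 mg/kg to 500 mg/kg.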

Compound 3, dose for half-maximal effect: > 100 mg/kg
Compound 3: a limit, no number; the forecaster's own chance of this, stated with the estimate: 80%; the middle value does not contradict the limit.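

Compound 3, like compound 2, stands only at a limit in this assay, so the step between compound 2 and compound 3 cannot be read. The compounds shown leave open at what dose any of them reaches the half-maximal effect, and how far a methyl on the chain or on the aromatic carbon shifts that dose.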